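Removing the aryl methyl from compound 1

A few compounds are considered here, and "the series" means these few. Any claim that something is new, unique, unknown or untested is made for them only; others in the source may bear on it.

Measured so far:
compound 1 `Cc1cccc(NC(=S)N/N=C/c2ccc3ccccc3n2)c1` — > 100000 nM
compound 2 `NC(=S)N/N=C/c1ccc2cccnc2n1` — > 100000 nM

In a functional assay on SGC-7901 cells (Homo sapiens) for antiproliferative activity, read by sulforhodamine B assay, with a stated time of 72 h (on this read-out higher numbers stand for weaker inhibition and lower numbers for stronger inhibition), compound 1 gives > 100000 nM, which is a limit of the assay and not a number. Compound 2 likewise gives > 100000 nM, again a limit. Both values sit at the limit of > 100000 nM in this assay, at which 2 of the 2 values shown sit. Compound 3 `S=C(N/N=C/c1ccc2ccccc2n1)Nc1ccccc1` differs from compound 1 by hydrogen in place of methyl on an aromatic carbon. For the measured compounds named here, no measured step in this assay is available for this change; the step of a number no higher from compound 1 to compound 3 (the limit leaves the size open) is expected to be none beyond the scatter, since compound 1 stands at > 100000 nM. Compound 3 is therefore expected to give 100000 nM, with a range from 30000 nM to 300000 nM.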

Compound 3, half-maximal inhibitory concentration: 26500 nM
Compound 3: middle estimate off by 3.8-fold (0.58 log units), on the high side; the measured number lies below the stated range.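

In this assay, going from 3-methylphenyl to phenyl brings an at least 3.7-fold lower number from compound 1 to compound 3 (0.57 log units; beyond the scatter), and compound 3 gives the first value among these compounds that is not a limit. The methyl at this position therefore matters to the read-out, although the full size of the step stays open because compound 1 sits at a limit: the limit of > 100000 nM in this assay, at which 2 of the 3 values shown sit.

Only methyl and hydrogen are compared at this position. Going by these compounds, how a chlorine, methoxy or amine would read there, or a methyl on another ring carbon, remains open.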